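Acylating the ring-bound nitrogen: an expectation for compound 3

The source may report more compounds than this note shows. Statements on the series, on what has been measured and on what is new or still open speak of the compounds shown alone.

Compound 1 `N#Cc1c(N)[n+]([O-])c2ccc(Cl)cc2[n+]1[O-]`: 71.3%
Compound 2 `CNc1c(C#N)[n+]([O-])c2cc(Cl)ccc2[n+]1[O-]`: 92.7%

In a functional assay on Ehrlich cells (Mus musculus) for cytotoxicity, read by trypan blue exclusion, with a stated time of 2 h, tested at 10 ug/mL (on this read-out higher numbers stand for a weaker effect at the one concentration tested and lower numbers for a stronger effect), compound 1 gives 71.3% and compound 2 gives 92.7%. Compound 2 therefore stands highest of the two numbers measured, with the step of a number 21.4 percentage points higher from compound 1 to compound 2 (beyond the scatter) placing it beyond the scatter above compound 1. Compound 3 `CC(=O)N(C(C)=O)c1c(C#N)[n+]([O-])c2cc(Cl)ccc2[n+]1[O-]` carries a further change at the same position: diacetylamino in place of methylamino on an aromatic carbon. Among the compounds with values here, only one measured step touches this nitrogen, the one from hydrogen to methyl, and it moved the read-out by the modest amount of a number 21.4 percentage points higher from compound 1 to compound 2 (beyond the scatter). Within the data shown here, no measured pair shows the effect of an acyl group here, so the direction is uncertain. Compound 3 is expected to give 88% in this assay, within 68% to 100%. That estimate amounts to a step of a number 4.7 percentage points lower from compound 2 to compound 3 (within the scatter), which is expected to stay within the scatter.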

Compound 3, a percentage reported as activity, at one concentration (the size of the read-out at that concentration, not a potency): 12.6%
Compound 3: middle estimate off by 75.4 percentage points, on the high side, and the stated range ends above it.
By their numbers in this assay, from the lowest: compound 3; then compound 1; then compound 2.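

In this assay this position on the aromatic carbon proves far more responsive than the change from hydrogen to methyl had shown: diacetylamino in place of methylamino gives a number 80.1 percentage points lower from compound 2 to compound 3 (beyond the scatter) and diacetylamino in place of amino gives a number 58.7 percentage points lower from compound 1 to compound 3 (beyond the scatter) on the same read-out. Both steps are large and beyond the scatter, so compound 3 has the strongest effect of the three compounds at the one concentration tested, and replacing either of the smaller nitrogen groups with diacetylamino takes the read-out the same way. No available evidence bears on why this change has so large an effect.

The compounds shown leave open whether a single acetyl, as in acetylamino, would already give such a drop or whether both acetyl groups are needed. They also leave open how a longer acyl chain, as in dipropionylamino, would compare.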